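A few compounds are considered here, and "the series" means these few. Any claim that something is new, unique, unknown or untested is made for them only; others in the source may bear on it.

Compound 2 `C=C(C)C(=O)N1CCC(CN(C2Cc3cc(C#N)ccc3N(Cc3cncn3C)C2)S(=O)(=O)c2ccccn2)CC1` gives 0.5 10^-6 cm/s in an ADME assay on Caco-2 cells (Homo sapiens) for permeability, in the apical to basolateral direction (on this read-out higher numbers stand for higher permeability and lower numbers for lower permeability), and stands level with compound 3 `CCCC(=O)N1CCC(CN(C2Cc3cc(C#N)ccc3N(Cc3cncn3C)C2)S(=O)(=O)c2ccccn2)CC1`, which gives 0.5 10^-6 cm/s; together they hold the highest of three numbers, while compound 1 `Cn1cncc1CN1CC(N(CC2CCN(S(C)(=O)=O)CC2)S(=O)(=O)c2ccccn2)Cc2cc(C#N)ccc21` gives the lowest at 0.1 10^-6 cm/s. The steps of a 5.0-fold higher number from compound 1 to compound 2 (0.70 log units; beyond the scatter) and a 5.0-fold higher number from compound 1 to compound 3 (0.70 log units; beyond the scatter) separate the two carbonyl compounds from the sulfonyl one, whereas no change at the digits printed from compound 2 to compound 3 (within the scatter).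

Compound 4 `Cn1cncc1CN1CC(N(CC2CCN(C(=O)CC(C)(C)C)CC2)S(=O)(=O)c2ccccn2)Cc2cc(C#N)ccc21` differs from compound 2 by neopentyl in place of 1-methylethenyl on a carbonyl carbon. The step most like it, from a 1-methylethenyl to a propyl group on the same carbonyl carbon, gave no change, so no step beyond the scatter is expected in this assay: compound 4 is estimated at 0.6 10^-6 cm/s, between 0.3 10^-6 cm/s and 1.2 10^-6 cm/s, meaning a 1.2-fold higher number from compound 2 to compound 4 (0.08 log units; within the scatter).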

Compound 4, apparent permeability: 0.5 10^-6 cm/s
Estimate against measurement, compound 4: 1.2-fold (0.08 log units) above; the measured number falls inside the stated range.
By their numbers in this assay, from the lowest: compound 1; then compounds 2, 3 and 4 (each within the scatter of the next).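

In this assay, the group on the carbonyl carbon can be neopentyl as well as 1-methylethenyl or propyl, with no change at the digits printed from compound 2 to compound 4 (within the scatter). The same holds for tert-butyl in place of ethyl on the saturated chain carbon bound to the carbonyl carbon, with no change at the digits printed from compound 3 to compound 4 (within the scatter). The neopentylcarbonyl group also keeps the gap to methylsulfonyl, with a 5.0-fold higher number from compound 1 to compound 4 (0.70 log units; beyond the scatter).

Nothing shown explains this gap between the carbonyl compounds and compound 1. Going by these compounds, whether a chain on the carbonyl carbon ending in an amine or a carboxylic acid would stay level with these compounds remains open.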